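The source may report more compounds than this note shows. Statements on the series, on what has been measured and on what is new or still open speak of the compounds shown alone.

Measured so far in an ADME assay on HCT-116 cells (Homo sapiens) for cytotoxicity, read by CellTiter-Glo, with a stated time of 72 h (on this read-out lower numbers stand for stronger inhibition and higher numbers for weaker inhibition), each entry being a limit of the assay and not a number:

- Compound 1 `CC1CCN(C2CCN(S(=O)(=O)c3cccnc3Cl)CC2)CC1`: > 10000 nM
- Compound 2 `CCc1ccc(S(=O)(=O)N2CCC(N3CCC(C)CC3)CC2)cc1`: > 5000 nM
- Compound 3 `CC1CCN(C2CCN(S(=O)(=O)c3cccc(Br)c3)CC2)CC1`: > 5000 nM

Compound 3 offers only a limit, > 5000 nM, and no number. That places it on (the limit of > 5000 nM in this assay, at which 2 of the 3 values shown sit), while the remaining compound sits on (the limit of > 10000 nM in this assay, at which 1 of the 3 values shown sits).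

Compound 4 `COc1ccc(Br)cc1S(=O)(=O)N1CCC(N2CCC(C)CC2)CC1` keeps the frame of compound 3 and takes one change: methoxy in place of hydrogen on an aromatic carbon. In words, a methoxy replaces a hydrogen on an aromatic carbon.

The measured steps nearest to this one are a step that the two limits leave unreadable from compound 1 to compound 3 and a step that the two limits leave unreadable from compound 2 to compound 3, both changes of the group on the sulfonyl sulfur. Among the measured compounds shown here, no measured step adds a methoxy, and none has a readable size. So no step beyond the scatter is expected in this assay, and no direction can be given.

The estimated step is a step that the limit leaves unreadable from compound 3 to compound 4. Compound 4 is expected at about 7000 nM, within an estimated range of 2500 nM to 15000 nM, and quite possibly as a limit again.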

Compound 4, half-maximal inhibitory concentration: > 5000 nM
Compound 4 was reported as a limit (the forecaster's own chance of this, stated with the estimate: 80%); the middle value does not contradict the limit.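

Compound 3 and compound 4 are both reported only as limits, not as numbers, so the size of the step that adds the methoxy cannot be read. The compounds shown leave open at what concentration any of them would reach half-maximal inhibition in this assay.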